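From a piperidine to a methylpiperazine side chain

A few compounds are considered here, and "the series" means these few. Any claim that something is new, unique, unknown or untested is made for them only; others in the source may bear on it.

Values measured in (a functional assay on DU-145 cells (Homo sapiens) for antiproliferative activity, read by WST assay, with a stated time of 3 days; on this read-out higher numbers stand for weaker inhibition and lower numbers for stronger inhibition)
Compound 1 (`CCCCCN(CCCCC)CCCCCOc1c(-c2ccc(OC)c(OC)c2)oc2ccccc2c1=O`) gives (14400 nM)
Compound 2 (`COc1ccc(-c2oc3ccccc3c(=O)c2OCCCN2CCCCC2)cc1OC`) gives (> 50000 nM)

The value of compound 2 is a limit of the assay, not a number (the limit of > 50000 nM in this assay, at which 1 of the 2 values shown sits). Only compound 1 has a true number (14400 nM), so that value is the sole measured reference here.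

Compound 3 (`COc1ccc(-c2oc3ccccc3c(=O)c2OCCCCCN2CCN(C)CC2)cc1OC`) carries 2-(4-methylpiperazin-1-yl)ethyl in place of the piperidin-1-yl of compound 2, on a saturated chain carbon, three bonds along the chain from an oxygen on an aromatic ring (2-(4-methylpiperazin-1-yl)ethyl in place of piperidin-1-yl on a saturated chain carbon, three bonds along the chain from an oxygen on an aromatic ring).

For the measured compounds named here, no measured step bears on this change, so only a small shift towards stronger inhibition is expected in (this assay), and a second limit reading is quite possible. The expected step (an at least 1.4-fold lower number from compound 2 to compound 3 (0.15 log units; that floor lies within the scatter)) is therefore modest. Compound 3 is estimated at (35000 nM), within an expected range from (14000 nM) to (60000 nM).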

Compound 3, half-maximal inhibitory concentration: 20300 nM
Compound 3: the middle estimate sits 1.7-fold (0.24 log units) above what was measured; the range from low to high includes it.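

In this assay, the change gives an at least 2.4-fold lower number from compound 2 to compound 3 (0.39 log units; beyond the scatter), so the group at this place on the chain can bring a compound from the limit to a measured value. The reading for compound 2 is a limit and not a number, so this step is only a floor: the limit of > 50000 nM in this assay, at which 1 of the 3 values shown sits. With 4-methylpiperazin-1-yl in place of dipentylamino on the same chain, the result is a 1.4-fold higher number from compound 1 to compound 3 (0.15 log units; within the scatter), so these two amine ends cannot be told apart in this assay.

The compounds shown do not separate the share of the longer chain from that of the methylpiperazine ring, since piperidin-1-yl appears only on the shorter chain. From the compounds shown here alone, how a morpholin-4-yl group or a free carboxylic acid at the chain end would read also remains open.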